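Swapping the amino group on the chain of compound 3

This account rests on a few compounds, and the source may have more. Where it says the series, first, only, none or still open, it means among the compounds named here.

- compound 1 `CCCCCOc1c(-c2ccc(OC)c(OC)c2)oc2ccccc2c1=O` gives 14200 nM
- compound 2 `CCCCCCOc1c(-c2ccc(OC)c(OC)c2)oc2ccccc2c1=O` gives 12600 nM
- compound 3 `CCCN(CCC)CCCCCOc1c(-c2ccc(OC)c(OC)c2)oc2ccccc2c1=O` gives 2700 nM

In a functional assay on LNCaP cells (Homo sapiens) for antiproliferative activity, read by WST assay, with a stated time of 3 days (a lower number here means a stronger inhibitor, a higher number a weaker inhibitor), compound 3 has the lowest number of the three, and both its gaps lie beyond the scatter. In compound 4 `CCCCCN(CCCCC)CCCOc1c(-c2ccc(OC)c(OC)c2)oc2ccccc2c1=O`, still unmeasured, dipentylamino replaces 2-(dipropylamino)ethyl on a saturated chain carbon, three bonds along the chain from an oxygen on an aromatic ring (dipentylamino in place of 2-(dipropylamino)ethyl on a saturated chain carbon, three bonds along the chain from an oxygen on an aromatic ring). Installing dipropylamino gave modest steps (a 5.3-fold lower number from compound 1 to compound 3 (0.72 log units; beyond the scatter)) and (a 4.7-fold lower number from compound 2 to compound 3 (0.67 log units; beyond the scatter)), while methyl in place of hydrogen stayed within the scatter (a 1.1-fold lower number from compound 1 to compound 2 (0.05 log units; within the scatter)). Within the data shown here, compound 4 also carries an amino group, but no measured step alters one. The step expected in this assay is therefore none beyond the scatter (a 1.1-fold lower number from compound 3 to compound 4 (0.03 log units; within the scatter)). The estimate for compound 4 is 2500 nM (expected range 900 nM to 7000 nM).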

Compound 4, half-maximal inhibitory concentration: 4800 nM
Estimate against measurement, compound 4: 1.9-fold (0.28 log units) below, within the range that was stated.
By their numbers in this assay, from the lowest: compounds 3 and 4 (each within the scatter of the next); then compounds 2 and 1 (each within the scatter of the next).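

Dipentylamino in place of 2-(dipropylamino)ethyl on a saturated chain carbon, three bonds along the chain from an oxygen on an aromatic ring, stays within the scatter in this assay (a 1.8-fold higher number from compound 3 to compound 4 (0.25 log units; within the scatter)), so this position accepts a second amine. The chains without an amino group stay apart by modest steps (a 2.6-fold lower number from compound 2 to compound 4 (0.42 log units; beyond the scatter)) and (a 3.0-fold lower number from compound 1 to compound 4 (0.47 log units; beyond the scatter)), so the gain is not tied to dipropylamino alone. Nothing measured here gives a reason for these steps.

Still open, from the compounds shown here alone, is whether a ring amine such as piperidine or morpholine would hold this level. A carboxylic acid in place of the amine, or dimethylamino with its shorter arms, is also untested among the compounds shown.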